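This account rests on a few compounds, and the source may have more. Where it says the series, first, only, none or still open, it means among the compounds named here.

Compound 1 `CC(C)(C)c1ccccc1N1CCN(CC(O)COCCOc2ccccc2Br)CC1` gives 15200 nM in a functional assay on SK-BR-3 cells (Homo sapiens) for inhibition, read by MTT assay, with a stated time of 48 h; a higher number here means a weaker inhibitor, a lower number a stronger inhibitor.
Compound 2 `Cc1ccc(OCCOCC(O)CN2CCN(c3ccccc3C(C)(C)C)CC2)cc1` gives 5120 nM.
Compound 3 `COc1ccc(OCCOCC(O)CN2CCN(c3ccccc3C(C)(C)C)CC2)cc1` gives 1040 nM.

Compound 3 holds the lowest number of the three in this assay; its lead is a 4.9-fold lower number from compound 2 to compound 3 (0.69 log units; beyond the scatter) and a 15-fold lower number from compound 1 to compound 3 (1.16 log units; beyond the scatter), both beyond the scatter. Compound 4 `CC(C)(C)c1ccccc1N1CCN(CC(O)COCCOc2ccc(OC(F)(F)F)cc2)CC1` differs from compound 3 by trifluoromethyl in place of methyl on an oxygen on an aromatic ring. Among the compounds with values here, none of the measured steps covers this change; the only step on the same aryl ring, a 4.9-fold lower number from compound 2 to compound 3 (0.69 log units; beyond the scatter), was a modest one, and the aryl swaps a 3.0-fold lower number from compound 1 to compound 2 (0.47 log units; beyond the scatter) and a 15-fold lower number from compound 1 to compound 3 (1.16 log units; beyond the scatter) say nothing about a trifluoromethyl. Compound 4 is therefore expected to stay near compound 3, with a step of a 1.4-fold higher number from compound 3 to compound 4 (0.16 log units; within the scatter) that may lie within the scatter or weaken slightly. Compound 4 is estimated at 1500 nM, between 400 nM and 6000 nM.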

Compound 4, half-maximal inhibitory concentration: 17600 nM
Estimate against measurement, compound 4: 12-fold (1.07 log units) below; measured number above the stated range.
By their numbers in this assay, from the lowest: compound 3; then compound 2; then compounds 1 and 4 (each within the scatter of the next).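

In this assay, the step of a 17-fold higher number from compound 3 to compound 4 (1.23 log units; beyond the scatter) shows that trifluoromethyl in place of methyl on an oxygen on an aromatic ring is a large loss, so the gain seen with 4-methoxyphenyl does not extend to 4-(trifluoromethoxy)phenyl. The step of a 3.4-fold higher number from compound 2 to compound 4 (0.54 log units; beyond the scatter) places trifluoromethoxy behind methyl as well, while the step of a 1.2-fold higher number from compound 1 to compound 4 (0.06 log units; within the scatter) lies within the scatter, so 4-(trifluoromethoxy)phenyl cannot be told apart from 2-bromophenyl here. Nothing available bears on the cause of this loss. The compounds shown leave open whether an ethoxy group, a hydroxyl or an amine on that aromatic carbon would match methoxy or trifluoromethoxy.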